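From compound 2 to compound 4: one aryl exchange

A few compounds are considered here, and "the series" means these few. Any claim that something is new, unique, unknown or untested is made for them only; others in the source may bear on it.

In a functional assay on SW-620 cells (Homo sapiens) for cytotoxicity (a lower number here means a stronger inhibitor of growth, a higher number a weaker inhibitor of growth), compound 1 `COc1ccc(C2=C(c3cc(OC)c(OC)c(OC)c3)CC3CCCN3C2=O)cc1O` gives > 100000 nM which is a limit of the assay and not a number. Compound 2 `CSc1ccc(C2=C(c3ccc(F)c(C)c3)C(=O)N3CCCC3C2)cc1` gives 600 nM as the lowest of the two numbers in hand. Compound 3 `COc1ccc(C2=C(c3ccc(SC)cc3)CC3CCCN3C2=O)cc1OC` gives 3000 nM and its gap to compound 2 lies beyond the scatter.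

Compound 4 `CSc1ccc(C2=C(c3ccc(C)cc3)C(=O)N3CCCC3C2)cc1` is not yet measured and differs from compound 2 in one place: 4-methylphenyl in place of 4-fluoro-3-methylphenyl on a double-bonded ring carbon with 4-methylphenyl in place of 4-fluoro-3-methylphenyl on a double-bonded ring carbon. For the measured compounds named here, no measured pair isolates this change. The expected step of a 1.5-fold higher number from compound 2 to compound 4 (0.18 log units; within the scatter) in this assay is small and toward a higher number, with none expected beyond the scatter. Compound 4 is estimated at 900 nM with 250 nM to 3000 nM as the expected range.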

Compound 4, concentration for 50% growth inhibition: 3000 nM
Compound 4: the middle estimate sits 3.3-fold (0.52 log units) below what was measured; the measured number falls inside the stated range.
By their numbers in this assay, from the lowest: compound 2; then compounds 3 and 4 (each within the scatter of the next). At a limit, above all of these: compound 1.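

In this assay the exchange of 4-fluoro-3-methylphenyl for 4-methylphenyl gives a 5.0-fold higher number from compound 2 to compound 4 (0.70 log units; beyond the scatter), the first step read at this double-bonded ring carbon. The step lies beyond the scatter, so the choice of aryl group here changes the read-out with the 4-(methylsulfanyl)phenyl group kept in place. Nothing shown accounts for this step.

Still open, on these data alone, is how the step divides between loss of the fluorine and the shift in the methyl pattern. Also open, as far as these compounds go, is how an aryl group carrying an amine or a carboxylic acid would read at this position.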